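This account rests on a few compounds, and the source may have more. Where it says the series, first, only, none or still open, it means among the compounds named here.

Measured compounds and values:

Compound 1 `CCS(=O)(=O)N(Cc1cccnc1)c1ccc(Cc2ccccc2)cc1` — in an assay on isolated protein with metabotropic glutamate receptor 2 (Homo sapiens) as the target (a lower number here means that less compound is needed, a higher number that more compound is needed for the effect), compound 1 gives 1600 nM.
Compound 2 `CCS(=O)(=O)N(Cc1cccnc1)c1cccc(Cc2ccccc2)c1` — in this assay compound 2 gives 310 nM.
Compound 3 `CCS(=O)(=O)N(Cc1cccnc1)c1ccc(C(F)c2ccccc2)cc1` — in this assay compound 3 reaches only a limit of the assay, > 30000 nM.

Compound 1 and compound 2 are built from the same atoms joined differently; the difference between the two cores is not broken down here. Of the two numbers, compound 2 holds the lower one and compound 1 the higher.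

Among the compounds with values here, the one structural change measured is fluoro in place of hydrogen on a saturated chain carbon bound to two aromatic carbons. It carries an at least 18-fold higher number from compound 1 to compound 3 (1.27 log units; beyond the scatter), and compound 3 sits at the limit of > 30000 nM in this assay, at which 1 of the 3 values shown sits, so the true size of that step is open upward.

Compound 4 `CCS(=O)(=O)N(Cc1cccnc1)c1cccc(C(F)c2ccccc2)c1` is the not yet measured partner: it carries fluoro in place of hydrogen on a saturated chain carbon bound to two aromatic carbons on the core of compound 2, the same change at the same kind of position as from compound 1 to compound 3. Set beside an at least 18-fold higher number from compound 1 to compound 3 (1.27 log units; beyond the scatter), the expected step is a 32-fold higher number from compound 2 to compound 4 (1.51 log units; beyond the scatter), resting on the one measured example, with a fair chance that compound 4 too ends at the limit. The estimate for compound 4 in this assay is 10000 nM, expected within 3000 nM to 40000 nM.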

Compound 4, half-maximal effective concentration: 180 nM
Compound 4: middle estimate off by 56-fold (1.74 log units), on the high side; the whole stated range lies above it.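

In this assay, fluoro in place of hydrogen on a saturated chain carbon bound to two aromatic carbons does not carry over from the core of compound 1 to the core of compound 2, as the two steps differ: the same change on two cores in this assay, an at least 18-fold higher number (1.27 log units; beyond the scatter) from compound 1 to compound 3 and a 1.7-fold lower number (0.24 log units; within the scatter) from compound 2 to compound 4, at least 32-fold (1.50 log units) apart, beyond the scatter of two such steps. On the core of compound 2 the change gives a 1.7-fold lower number from compound 2 to compound 4 (0.24 log units; within the scatter), so compound 4 cannot be told apart from compound 2; with one pair on each core, this shows that the outcome of the change depends on the core, but neither which feature of the core decides it nor how other cores would respond. From the compounds shown here alone, the step on the core of compound 1 ends at a limit of the assay, so its true size, and with it the full gap between the two steps, stays open: the limit of > 30000 nM in this assay, at which 1 of the 4 values shown sits.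

Open, going by these compounds, is whether a hydroxyl, a methyl or an amine on that same chain carbon would split the two cores in the same way. Also open, on these data alone, is whether a carbonyl in place of that chain carbon would follow either core's pattern.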